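The source may report more compounds than this note shows. Statements on the series, on what has been measured and on what is new or still open speak of the compounds shown alone.

Compounds measured so far: compound 1, `COc1ccc(/C(=C/c2ccc(OC)c(O)c2)c2cc(OC)c(OC)c(OC)c2)cc1`; compound 2, `COc1ccc(/C=C(/c2ccc(C)cc2)c2cc(OC)c(OC)c(OC)c2)cc1O`.

In a functional assay on HCT-116 cells (Homo sapiens) for cytotoxicity, with a stated time of 72 h (a higher number here means a weaker inhibitor, a lower number a stronger inhibitor), compound 1 gives > 10000 nM, which is a limit of the assay rather than a number. In this assay compound 2 gives 3000 nM. Compound 2 thus holds the only number shown; the other value is a limit, as noted in the limit of > 10000 nM in this assay, at which 1 of the 2 values shown sits.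

Within the data shown here, the single measured step, methyl in place of methoxy on an aromatic carbon, is an at least 3.3-fold lower number from compound 1 to compound 2 (0.52 log units; beyond the scatter), so the compound carrying methyl gave the smaller number.

Compound 3, `COc1ccc(/C=C(/c2ccc(OC)c(O)c2)c2cc(OC)c(OC)c(OC)c2)cc1O`, has not yet been measured. Its change from compound 2 is 3-hydroxy-4-methoxyphenyl in place of 4-methylphenyl on a double-bonded chain carbon bound to an aromatic carbon and a double-bonded chain carbon. The measured step bears on this only in part: it removed methoxy from the group on this same chain carbon and lowered the number, and the group entering here brings methoxy back together with a hydroxy. On that basis the step is expected to be a 2.7-fold higher number from compound 2 to compound 3 (0.43 log units; beyond the scatter), toward a weaker inhibitor in this assay, with a fair chance that only a limit is reported. Compound 3 is therefore estimated at 8000 nM, in a range from 2500 nM to 30000 nM.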

Compound 3, half-maximal inhibitory concentration: 5000 nM
Compound 3: middle estimate off by 1.6-fold (0.20 log units), on the high side; low and high end bracket the measured number.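

At this chain carbon, this assay does not separate 3-hydroxy-4-methoxyphenyl from 4-methylphenyl: the exchange gives a 1.7-fold higher number from compound 2 to compound 3 (0.22 log units; within the scatter). The earlier step, with methyl in place of methoxy, might have suggested that methoxy on this aromatic group always costs activity, but compound 3 carries a methoxy there and cannot be told apart from compound 2, which carries a methyl. Hydroxy in place of hydrogen on an aromatic carbon gives an at least 2.0-fold lower number from compound 1 to compound 3 (0.30 log units; that floor lies within the scatter), a floor rather than a size, as compound 1 stands at a limit of the assay: the limit of > 10000 nM in this assay, at which 1 of the 3 values shown sits.

Among these compounds, only two aromatic groups can be compared at this chain carbon, so it remains open whether any other group there would move the number beyond the scatter, for instance a phenyl ring bearing an amine, a carboxylic acid or a fluorine. On these data alone, the real size of the hydroxy step also remains open, as does whether a longer alkoxy chain in place of that hydroxy would give a different number.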